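Adding one methoxy group to compound 3

This account rests on a few compounds, and the source may have more. Where it says the series, first, only, none or still open, it means among the compounds named here.

Compound 1 `COc1cc(OC)c(OC)cc1/C=C/C(=O)/C=C/c1cc2ccccc2nc1Oc1ccccc1`: 7290 nM
Compound 2 `COc1ccc(/C=C/C(=O)/C=C/c2cc3ccccc3nc2Oc2cccc(Cl)c2)c(OC)c1`: > 10000 nM (a limit)
Compound 3 `COc1ccc(/C=C/C(=O)/C=C/c2cc3ccccc3nc2Oc2cccc(Cl)c2)cc1OC`: > 10000 nM (a limit)

All three were tested in a functional assay on PC-3 cells (Homo sapiens) for cytotoxicity, read by MTT assay, with a stated time of 48 h; on this read-out lower numbers stand for stronger inhibition and higher numbers for weaker inhibition. Compound 3 gives no number there, only the limit > 10000 nM. Compound 2 also gives only a limit, > 10000 nM. Together they make up the following: the limit of > 10000 nM in this assay, at which 2 of the 3 values shown sit.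

Compound 4 `COc1cc(OC)c(OC)cc1/C=C/C(=O)/C=C/c1cc2ccccc2nc1Oc1cccc(Cl)c1` differs from compound 3 by one change: methoxy in place of hydrogen on an aromatic carbon. The 3,4-dimethoxyphenyl thus becomes 2,4,5-trimethoxyphenyl.

Among the compounds with values here, the one measured step, a step that the two limits leave unreadable from compound 2 to compound 3, gives no size to build on. Within the data shown here, the only guide is compound 1, the sole measured compound with 2,4,5-trimethoxyphenyl, which gives 7290 nM. On that single value, a small gain in strength in this assay is expected, though a result that is again only a limit remains quite possible.

The expected change is estimated as an at least 1.1-fold lower number from compound 3 to compound 4 (0.07 log units; that floor lies within the scatter).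

For compound 4 the estimated value is 8500 nM, with an expected range of 3500 nM to 20000 nM.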

Compound 4, half-maximal inhibitory concentration: > 10000 nM
Compound 4 ended at the assay's limit; the forecaster's own chance of this, stated with the estimate: 45%; middle value at least 1.1-fold (0.07 log units) from the limit.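

In this assay the added methoxy group, ortho to a large group, does not bring the chloro compound 4 to a readable number: compound 4 gives > 10000 nM, which is a limit. Within the data shown here, the only step that can be read concerns the chloro group, and an at least 1.3-fold higher number from compound 1 to compound 4 (0.13 log units; that floor lies within the scatter) is too small at its floor to establish that chloro costs strength. The steps that add the methoxy group cannot be read, and the values gather further at one point: the limit of > 10000 nM in this assay, at which 3 of the 4 values shown sit.

Whether methoxy at this position changes strength at all stays open, since none of the compounds shown pairs the change with two numbers. Also open, on these data alone, is whether an amine in place of the chloro would give a number in this assay rather than a limit.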